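A Second Methoxy Group and Its Expected Cytotoxicity

A few compounds are considered here, and "the series" means these few. Any claim that something is new, unique, unknown or untested is made for them only; others in the source may bear on it.

Compound 1 `COc1ccc(-c2cc(/C=C/C(=O)c3ccc(N)cc3)[nH]n2)cc1` carries a single methoxy group on the ring joined to the shared core and an amino group on the ring joined to the carbonyl. In a functional assay on SNB-19 cells (Homo sapiens) for cytotoxicity, read by sulforhodamine B assay, with a stated time of 48 h, tested at 100 uM (on this read-out higher numbers stand for a weaker effect at the one concentration tested and lower numbers for a stronger effect), compound 1 gives -80%, the lowest of the three numbers recorded, which on this read-out means the strongest effect. Compound 2 `COc1cc(-c2cc(/C=C/C(=O)c3ccc(Cl)c(Cl)c3)[nH]n2)cc(OC)c1OC` gives 12% and compound 3 `COc1cc(-c2cc(/C=C/C(=O)c3ccc(F)c(F)c3)[nH]n2)cc(OC)c1OC` gives 22%, both beyond the scatter from compound 1. Going by the values given here, the only recorded step, a number 10 percentage points higher from compound 2 to compound 3 (within the scatter), changes the ring on the carbonyl and lies within the scatter. Compound 4 `COc1ccc(-c2cc(/C=C/C(=O)c3ccc(N)cc3)[nH]n2)cc1OC` differs from compound 1 by methoxy in place of hydrogen on an aromatic carbon. Among the compounds with values here, no recorded step changes this ring alone: compound 2 and compound 3 carry three methoxy groups there but also a different ring on the carbonyl, so their numbers cannot be separated into the two changes. Within the data shown here, with no direct precedent, the expected step is a number 5 percentage points higher from compound 1 to compound 4 (within the scatter), that is, none beyond the scatter. Compound 4 is therefore estimated at -75%, in a range from -105% to -30%.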

Compound 4, a percentage reported as activity, at one concentration (the size of the read-out at that concentration, not a potency): -91%
Beside the measured number, compound 4's estimate is 16 percentage points above it, within the range that was stated.
By their numbers in this assay, from the lowest: compound 4; then compound 1; then compounds 2 and 3 (each within the scatter of the next).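

With the amino ring on the carbonyl held fixed, methoxy in place of hydrogen on an aromatic carbon, ortho to a methoxy group, gives in this assay a clean single-change comparison: a number 11 percentage points lower from compound 1 to compound 4 (beyond the scatter). On this read-out a lower number means a stronger effect, so this position takes a second methoxy group with a modest gain rather than a loss, something compounds 2 and 3 could not show since they also differ in the ring on the carbonyl. Nothing available explains the gain.

Going by these compounds, whether this gain belongs to methoxy itself remains open, as a hydroxyl group or an ethoxy group at the same position would be needed to tell. Also open, on these data alone, is whether a third methoxy group would strengthen the effect further while the amino ring stays in place.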